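The source may report more compounds than this note shows. Statements on the series, on what has been measured and on what is new or still open speak of the compounds shown alone.

Measured compounds, with their values in a functional assay on HEp-2 cells (Homo sapiens) for antiproliferative activity, read by MTT assay, with a stated time of 72 h; a higher number here means a weaker inhibitor, a lower number a stronger inhibitor:

- compound 1 `COc1ccc2occ(CSC(=S)N(C(C)C)C(C)C)c(=O)c2c1`: 8900 nM
- compound 2 `CN1CCN(C(=S)SCc2coc3ccccc3c2=O)CC1`: 2400 nM
- compound 3 `Cc1ccc2c(=O)c(CSC(=S)N(C(C)C)C(C)C)coc2c1`: 700 nM

Compound 3 gives the lowest number of the three in this assay, and both gaps to it are beyond the scatter: compound 2 sits some way above it, and compound 1 further still. Compound 1 and compound 3 share the same dithiocarbamate side; compound 2 carries a different amine and an unsubstituted benzene side of the core.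

Compound 4 `CC(C)N(C(=S)SCc1coc2ccccc2c1=O)C(C)C` has not yet been measured. From compound 3 it differs in one place: hydrogen in place of methyl on an aromatic carbon. Within the data shown here, no step between two measured compounds isolates this change; the closest comparison is compound 2, which also has the unsubstituted ring but a different amine, and which sits above compound 3.

Losing the methyl is expected to cost some activity in this assay, a step of moderate size in the direction of a higher number, plausibly beyond the scatter but not large; the expected step is a 2.1-fold higher number from compound 3 to compound 4 (0.33 log units; beyond the scatter). Compound 4 is estimated at 1500 nM in this assay, within a range from 500 nM to 5000 nM.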

Compound 4, half-maximal inhibitory concentration: 3000 nM
Compound 4: middle estimate off by 2.0-fold (0.30 log units), on the low side; measured number inside the range.
By their numbers in this assay, from the lowest: compound 3; then compounds 2 and 4 (each within the scatter of the next); then compound 1.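

In this assay, among these compounds, removing the methyl from the aromatic carbon gives a 4.3-fold higher number from compound 3 to compound 4 (0.63 log units; beyond the scatter), the first direct reading of this position and evidence that the methyl-bearing compound owes part of its lower number to this single-carbon group. Replacing methoxy with hydrogen at a different aromatic carbon runs the opposite way, with a 3.0-fold lower number from compound 1 to compound 4 (0.47 log units; beyond the scatter), so within these compounds a substituent on the benzene side of the shared core can go with either a lower or a higher number, depending on the group and where it stands. With the unsubstituted ring, the change of amine gives a 1.3-fold higher number from compound 2 to compound 4 (0.10 log units; within the scatter), which is within the scatter and separates diisopropylamino from 4-methylpiperazin-1-yl by nothing that can be read, and no accompanying data bear on the reason for any of these steps.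

Still open, as far as these compounds go, is whether an ethyl group, a chlorine or a methoxy at the methyl-bearing carbon would match or exceed the methyl. Also open, from the compounds shown here alone, is whether the methyl would give a similar step alongside 4-methylpiperazin-1-yl, or whether its effect is tied to diisopropylamino.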